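From tert-Butyl to Ethoxycarbonyl on the Shared Core

This account rests on a few compounds, and the source may have more. Where it says the series, first, only, none or still open, it means among the compounds named here.

Measured in a functional assay on M21 cells (Homo sapiens) for antiproliferative activity, read by sulforhodamine B assay, with a stated time of 48 h; on this read-out higher numbers stand for weaker inhibition of growth and lower numbers for stronger inhibition of growth:
- compound 1, `NS(=O)(=O)NCC1CCN(c2cc(-c3ccccc3)ncn2)CC1`: > 100000 nM, a limit of the assay
- compound 2, `CC(C)(C)c1ccc(-c2cc(N3CCC(CNS(N)(=O)=O)CC3)ncn2)cc1`: 19300 nM

Among the compounds with values here, compound 2 holds the only number here; for compound 1 only the limit of > 100000 nM in this assay, at which 1 of the 2 values shown sits, is known. Compound 3, `CCOC(=O)c1ccc(-c2cc(N3CCC(CNS(N)(=O)=O)CC3)ncn2)cc1`, differs from compound 2 by ethoxycarbonyl in place of tert-butyl on an aromatic carbon. Within the data shown here, the one measured step, an at least 5.1-fold lower number from compound 1 to compound 2 (0.71 log units; beyond the scatter), shows that a group in place of hydrogen at this carbon lowers the number, yet no measured step swaps tert-butyl for ethoxycarbonyl, so the direction for compound 3 is open. Compound 3 is therefore expected near compound 2 or somewhat higher, a 2.1-fold higher number from compound 2 to compound 3 (0.32 log units; beyond the scatter), an estimate of 40000 nM in this assay (range 8000 nM to 150000 nM).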

Compound 3, concentration for 50% growth inhibition: 5000 nM
Estimate against measurement, compound 3: 8.0-fold (0.90 log units) above, outside the stated range (below it).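

In this assay, the identity of the group on this aromatic carbon matters, not merely the presence of a group: ethoxycarbonyl in place of tert-butyl gives a 3.9-fold lower number from compound 2 to compound 3 (0.59 log units; beyond the scatter). Ethoxycarbonyl in place of hydrogen gives an at least 20-fold lower number from compound 1 to compound 3 (1.30 log units; beyond the scatter). The size of this second step is open-ended, as compound 1 is known only through a limit: the limit of > 100000 nM in this assay, at which 1 of the 3 values shown sits.

The compounds shown do not tell which part of ethoxycarbonyl, its carbonyl or its ethyl chain, goes with the lower number. A carboxylic acid or a methyl ester at this carbon would bear on that question.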